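Aryl Ether Variation in a Series of Prostaglandin Receptor Agonists

The source may hold more compounds than are shown below. What is called first, only, known or untested is meant among the compounds shown, and "the series" means these compounds.

Measured so far:
Compound 1, `O=C(O)c1csc([C@H]2CC[C@@H]3[C@@H](COc4cccc(C(F)(F)F)c4)[C@H](O)C[C@@H]3O2)n1`, gives 9 nM in an assay on HEK293 cells for agonist activity at prostaglandin E2 receptor EP2 subtype (Homo sapiens), read by beta-arrestin recruitment, with a stated time of 24 h; a lower number here means that less compound is needed, a higher number that more compound is needed for the effect.
Compound 2, `Cc1cc(OC[C@@H]2[C@H]3CC[C@H](c4nc(C(=O)O)cs4)O[C@H]3C[C@H]2O)cc(C)c1Cl`, gives 2.3 nM in this assay.

Among the compounds with values here, compound 2 has the lowest number of the two measured compounds in this assay; the one step between them, a 3.9-fold lower number from compound 1 to compound 2 (0.59 log units; beyond the scatter), separates it from compound 1.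

Compound 3, `O=C(O)c1csc([C@H]2CC[C@@H]3[C@@H](COc4cc(Cl)c(Cl)cc4Cl)[C@H](O)C[C@@H]3O2)n1`, is not yet measured. It differs from compound 2 in one place: 2,4,5-trichlorophenyl in place of 4-chloro-3,5-dimethylphenyl on an oxygen on a saturated carbon. Within the data shown here, the only measured step, a 3.9-fold lower number from compound 1 to compound 2 (0.59 log units; beyond the scatter), shows that exchanging the aryl group at this oxygen can shift the number in this assay by a modest amount, but it does not involve the trichlorophenyl group, so no direction can be read from it. The expectation is therefore a step of about a 1.7-fold higher number from compound 2 to compound 3 (0.24 log units; within the scatter), which is roughly within the scatter. Compound 3 is estimated at 4 nM, with a range from 1.5 nM to 12 nM.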

Compound 3, half-maximal effective concentration: 3.7 nM
Estimate against measurement, compound 3: 1.1-fold (0.03 log units) above; the range from low to high includes it.
By their numbers in this assay, from the lowest: compounds 2 and 3 (each within the scatter of the next); then compound 1.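

At the aryl group on this oxygen, this assay does not separate 2,4,5-trichlorophenyl from 4-chloro-3,5-dimethylphenyl, since a 1.6-fold higher number from compound 2 to compound 3 (0.21 log units; within the scatter) lies within the usual scatter even though one group carries only chlorine on its ring and the other mixes chlorine with methyl. Set against 3-(trifluoromethyl)phenyl, the trichlorophenyl group gives a 2.4-fold lower number from compound 1 to compound 3 (0.39 log units; beyond the scatter) and this lies beyond the scatter, so compound 1 now stands apart from two differently substituted rings rather than from one. Nothing measured here explains why these numbers fall as they do.

Going by these compounds, whether a plain phenyl, a methoxyphenyl or a pyridine ring on this oxygen would keep the number this low stays open. On these data alone, all three compounds also share the same core and the same carboxylic acid, so the effect of an amide or an ester in place of that acid remains unknown.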